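This account rests on a few compounds, and the source may have more. Where it says the series, first, only, none or still open, it means among the compounds named here.

Measured so far in an assay on microsomes from brain for inhibition of Fatty-acid amide hydrolase 1 (Rattus norvegicus), read by fluorescence and HPLC, with a stated time of 60 min; on this read-out higher numbers stand for weaker inhibition and lower numbers for stronger inhibition:
Compound 1 `CCCCCCCCc1ccc(OCC(=O)Cn2nnc(C)n2)cc1` gives 27 nM.
Compound 2 `CCCCCCCCc1ccc(OCC(=O)Cn2nnc(-c3ccc(C(=O)OC)cc3)n2)cc1` gives 29 nM.
Compound 3 `CCCCCCCCc1ccc(OCC(=O)Cn2nnc(-c3cccc(S(=O)(=O)N(C)C)c3)n2)cc1` gives 420 nM.

Compound 3 stands at the highest number of the three: its step of a 16-fold higher number from compound 1 to compound 3 (1.19 log units; beyond the scatter) and its step of a 14-fold higher number from compound 2 to compound 3 (1.16 log units; beyond the scatter) both lie beyond the scatter, while a 1.1-fold higher number from compound 1 to compound 2 (0.03 log units; within the scatter) does not. Compound 4 `CCCCCCCCc1ccc(OCC(=O)Cn2nnc(-c3ccncc3)n2)cc1` differs from compound 3 in one place: pyridin-4-yl in place of 3-(dimethylsulfamoyl)phenyl on an aromatic carbon. Going by the values given here, the steps from compound 1 and compound 2 to compound 3 show that the 3-(dimethylsulfamoyl)phenyl group went with a large rise; a six-membered aromatic ring with one hetero atom has no direct precedent here, but the methyl and 4-(methoxycarbonyl)phenyl groups in this assay gave similar numbers, so a large step downward is expected in this assay, a 9.3-fold lower number from compound 3 to compound 4 (0.97 log units; beyond the scatter). Compound 4 is estimated at 45 nM, in the range 15 nM to 150 nM.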

Compound 4, half-maximal inhibitory concentration: 24 nM
Estimate against measurement, compound 4: 1.9-fold (0.27 log units) above; measured number inside the range.
By their numbers in this assay, from the lowest: compounds 4, 1 and 2 (each within the scatter of the next); then compound 3.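

In this assay, pyridin-4-yl at this position restores the low numbers lost with 3-(dimethylsulfamoyl)phenyl (an 18-fold lower number from compound 3 to compound 4 (1.24 log units; beyond the scatter)). It also stands level with the other two groups (a 1.2-fold lower number from compound 2 to compound 4 (0.08 log units; within the scatter); a 1.1-fold lower number from compound 1 to compound 4 (0.05 log units; within the scatter)), so a six-membered aromatic ring with 1 hetero atom fits the pattern of methyl and 4-(methoxycarbonyl)phenyl, and of the four groups only 3-(dimethylsulfamoyl)phenyl stands apart. No supporting information bears on why that group differs. Still open, from the compounds shown here alone, is whether the rise follows the dimethylsulfamoyl group itself or its place on the phenyl ring, as 4-(dimethylsulfamoyl)phenyl would show. Going by these compounds, how an amine or a carboxylic acid on that phenyl ring would read also remains unknown.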